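The compounds below may be only part of what the source reports. "The series", "measured", "known", "first", "only" and "open" are said of these compounds alone.

Measured so far in an in vitro ADME assay on microsomes from liver (Rattus norvegicus) for metabolic stability, read by LC-MS, tested at 1 uM; on this read-out higher numbers stand for fast clearance and lower numbers for slow clearance:

- Compound 1 `O=C(O)COc1ccc(Cl)cc1C#Cc1ccc(CO)cc1F`: < 10 mL.min-1.g-1
- Compound 2 `COCCNS(=O)(=O)c1ccc(C)c(C#Cc2cc(Cl)ccc2OCC(=O)O)c1`: < 10 mL.min-1.g-1

Neither entry is an exact number, and the two compounds cannot be ranked against each other. Compound 2 gives < 10 mL.min-1.g-1, which is a limit of the assay and not a number. Compound 2 therefore stands at the limit of < 10 mL.min-1.g-1 in this assay, at which 2 of the 2 values shown sit.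

The next compound to be tested is compound 3 `Cc1ccc(S(=O)(=O)N(C)C)cc1C#Cc1cc(Cl)ccc1OCC(=O)O`. It keeps the core of compound 2 and changes one group, with dimethylamino in place of (2-methoxyethyl)amino on a sulfonyl sulfur. Going by the values given here, no pair of measured compounds differs in just one place, so there is no direct measurement of what a swap like this does in this assay.

Among the compounds with values here, the only close reference is compound 2 at < 10 mL.min-1.g-1, so no shift beyond the usual scatter is expected, in either direction. The expected change is a step that the limit leaves unreadable from compound 2 to compound 3. A further limit, rather than a number, would be no surprise. For compound 3 the estimated value is 9 mL.min-1.g-1, with an expected range from 5 mL.min-1.g-1 to 20 mL.min-1.g-1.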

Compound 3, intrinsic clearance in microsomes: 22 mL.min-1.g-1
Beside the measured number, compound 3's estimate is 2.4-fold (0.39 log units) below it; the measured number lies above the stated range.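

In this assay, going by these compounds alone, the change on the sulfonyl sulfur gives an at least 2.2-fold higher number from compound 2 to compound 3 (0.34 log units; beyond the scatter), the first measured step at this position and the first sign that the read-out responds to the group placed there. Dimethylamino is the smaller group, and it also brings neither the hydrogen-bond donor nor the acceptor counted for (2-methoxyethyl)amino, so several things change in this one swap and no single one can be picked out as responsible. Only the minimum size of the step can be stated, and its true size stays unknown because the starting point is a limit of the assay and not a number: the limit of < 10 mL.min-1.g-1 in this assay, at which 2 of the 3 values shown sit.

The compounds shown leave open whether the higher clearance goes with the loss of the hydrogen on the sulfonamide nitrogen or with the loss of the methoxyethyl chain, and a methylamino group on the same sulfur would help to separate the two. As far as these compounds go, it also remains open how a ring amine such as morpholine or a longer chain such as (3-methoxypropyl)amino would read at this position.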